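From methoxy to methyl at the assay limit

This account rests on a few compounds, and the source may have more. Where it says the series, first, only, none or still open, it means among the compounds named here.

Measured in a functional assay on KB cells (Homo sapiens) for inhibition; a higher number here means a weaker inhibitor, a lower number a stronger inhibitor:
- Compound 1 `Clc1cc2nc(Cl)n(Cc3ccccc3)c2cc1Cl` gives > 100000 nM as a limit
- Compound 2 `COc1ccc(Cn2c(Cl)nc3cc(Cl)c(Cl)cc32)cc1` gives > 100000 nM as a limit

Compound 2 stands at > 100000 nM in this assay and that entry is a limit, not a number. Among the compounds with values here, compound 1 offers no number either, so all that can be said of the series so far is the limit of > 100000 nM in this assay, at which 2 of the 2 values shown sit, and nothing finer.

Compound 3 `Cc1ccc(Cn2c(Cl)nc3cc(Cl)c(Cl)cc32)cc1` carries methyl in place of methoxy on an aromatic carbon, para to a large group (methyl in place of methoxy on an aromatic carbon). Within the data shown here, the only measured step bearing on this is a step that the two limits leave unreadable from compound 1 to compound 2 and it put methoxy in place of hydrogen on an aromatic carbon, so it offers no size to carry over. Going by that step, no change beyond the usual scatter is expected in this assay and no direction can be named. The estimated move is a number no higher from compound 2 to compound 3 (the limit leaves the size open) and it remains only an expectation. Compound 3 is estimated at 100000 nM with an expected range from 30000 nM to 300000 nM and the assay will most likely report only a limit again.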

Compound 3, half-maximal inhibitory concentration: > 100000 nM
Compound 3: a limit, no number; the forecaster's own chance of this, stated with the estimate: 85%; the middle value sits exactly at the limit.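

Compound 3 gives > 100000 nM in this assay, and this is again a limit, not a number. Within the data shown here, no step among compound 1, compound 2 and compound 3 can be read, and the series shows only this: the limit of > 100000 nM in this assay, at which 3 of the 3 values shown sit. The compounds shown leave open how strongly any of them inhibits and whether hydrogen, methoxy or methyl at this place makes any difference.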